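This account rests on a few compounds, and the source may have more. Where it says the series, first, only, none or still open, it means among the compounds named here.

Measured in a functional assay on HepG2 cells (Homo sapiens) for antiproliferative activity, read by MTT assay, with a stated time of 48 h; a lower number here means a stronger inhibitor, a higher number a weaker inhibitor:
- compound 1 `O=C(/C=C/c1cn(S(=O)(=O)c2cccc([N+](=O)[O-])c2)c2ccccc12)c1ccncc1`: 42600 nM
- compound 2 `CCCS(=O)(=O)n1cc(/C=C/C(=O)c2ccncc2)c2ccccc21`: 46200 nM

Compound 2, at 46200 nM, sits within the scatter of compound 1. Compound 3 `CC(C)(C)c1ccc(S(=O)(=O)n2cc(/C=C/C(=O)c3ccncc3)c3ccccc32)cc1` keeps the shared core but carries 4-(tert-butyl)phenyl in place of propyl on a sulfonyl sulfur. Within the data shown here, only one measured step bears on this change. It swapped the group on that same sulfur, and a 1.1-fold higher number from compound 1 to compound 2 (0.04 log units; within the scatter) stayed within the scatter. Among the measured compounds shown here, no measured compound carries the new group, so the range stays wide. In this assay, no step beyond the scatter is therefore expected, and the estimated step is a 1.2-fold lower number from compound 2 to compound 3 (0.08 log units; within the scatter). The estimate for compound 3 is 38000 nM, with an expected range of 16000 nM to 80000 nM.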

Compound 3, half-maximal inhibitory concentration: 27000 nM
Compound 3: middle estimate off by 1.4-fold (0.15 log units), on the high side, and the stated range covers the measured number.
By their numbers in this assay, from the lowest: compounds 3, 1 and 2 (each within the scatter of the next).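

In this assay, swapping propyl for 4-(tert-butyl)phenyl on the sulfonyl sulfur gives a 1.7-fold lower number from compound 2 to compound 3 (0.23 log units; within the scatter), and swapping 3-nitrophenyl for it gives a 1.6-fold lower number from compound 1 to compound 3 (0.20 log units; within the scatter). Even adding an aromatic ring and reaching 10 heavy atoms in this position therefore leaves all three compounds within the scatter of one another. No measurement here explains the small differences. On these data alone, it remains open whether a simple phenyl, an amine-bearing chain or a carboxylic acid on this sulfur would shift the number beyond the scatter.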